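The source may hold more compounds than are shown below. What is called first, only, known or untested is meant among the compounds shown, and "the series" means these compounds.

Among the measured compounds shown here, in a functional assay on RAW264.7 cells (Mus musculus) for inhibition, read by Griess assay, with stated times of 2 h and 24 h (a lower number here means a stronger inhibitor, a higher number a weaker inhibitor), compound 2 `COc1ccc([C@@H]2CC(=O)c3c(O)cc(OCc4cn(Cc5cccc(C(F)(F)F)c5)nn4)cc3O2)cc1O` gives 19900 nM, the higher of the two numbers so far; compound 1 `CCCn1cc(COc2cc(O)c3c(c2)O[C@H](c2ccc(OC)c(O)c2)CC3=O)nn1` gives 9670 nM, and the one measured step, a 2.1-fold higher number from compound 1 to compound 2 (0.31 log units; beyond the scatter), is modest. Compound 3 `COc1ccc([C@@H]2CC(=O)c3c(O)cc(OCc4cn(Cc5ccc(F)cc5)nn4)cc3O2)cc1O` differs from compound 2 by 4-fluorophenyl in place of 3-(trifluoromethyl)phenyl on a saturated chain carbon bound to an aromatic nitrogen. For the measured compounds named here, no measured step matches this change; the measured step only shows that placing the trifluoromethyl-bearing ring there cost a little, so any shift here is expected to be small. Compound 3 is therefore expected to sit close to compound 2, a step of a 1.3-fold lower number from compound 2 to compound 3 (0.12 log units; within the scatter), at an estimated 15000 nM with a range of 7000 nM to 35000 nM.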

Compound 3, half-maximal inhibitory concentration: 15100 nM
Beside the measured number, compound 3's estimate is 1.0-fold (0.00 log units) below it; the measured number falls inside the stated range.
By their numbers in this assay, from the lowest: compounds 1, 3 and 2 (each within the scatter of the next, the first and the last beyond it).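

Placing 4-fluorophenyl where 3-(trifluoromethyl)phenyl stood, on a saturated chain carbon bound to an aromatic nitrogen, gives a 1.3-fold lower number from compound 2 to compound 3 (0.12 log units; within the scatter), so this assay does not tell these two rings apart. Placing 4-fluorophenyl where ethyl stood gives a 1.6-fold higher number from compound 1 to compound 3 (0.19 log units; within the scatter), so a ring at this place need not cost anything measurable, although the ring in compound 2 did. Nothing measured here explains these numbers.

The compounds shown carry only ethyl or a fluorine-bearing phenyl ring at this place. From the compounds shown here alone, what an amine, a carboxylic acid or a longer chain would do there stays open.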